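Swapping the nitrophenyl arm for hydroxymethyl: cytotoxicity outlook

The source may hold more compounds than are shown below. What is called first, only, known or untested is meant among the compounds shown, and "the series" means these compounds.

Compound 1 `O=c1n([C@H]2CO[C@@H](CO)O2)ccc2nc(-c3ccc([N+](=O)[O-])cc3)cn12` gives 486000 nM in an ADME assay on HepG2 2.2.15 cells (Homo sapiens) for cytotoxicity, read by neutral red uptake; on this read-out lower numbers stand for higher toxicity in this test and higher numbers for lower toxicity in this test.
Compound 2 `O=c1n([C@H]2CO[C@@H](CO)O2)cc(F)c2nc(-c3ccc([N+](=O)[O-])cc3)cn12` gives 1390000 nM in this assay.
Compound 3 `O=c1n([C@H]2CO[C@H](CO)O2)cc(F)c2nc(-c3ccc([N+](=O)[O-])cc3)cn12` gives 587000 nM in this assay.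

Among these three, compound 2 stands highest in this assay; its neighbours lie a 2.9-fold higher number from compound 1 to compound 2 (0.46 log units; beyond the scatter) and a 2.4-fold lower number from compound 2 to compound 3 (0.37 log units; beyond the scatter). Compound 4 `O=c1n([C@H]2CO[C@@H](CO)O2)cc(F)c2nc(CO)cn12` differs from compound 2 in one place: hydroxymethyl in place of 4-nitrophenyl on an aromatic carbon. Neither measured step touches this group: the first concerned fluoro on the core, the second only configuration, since (the fact that compounds 2 and 3 differ only in the configuration as drawn). Going by the values given here, no measured step therefore bears on the exchange, and the expectation can only rest on the position of compound 2 at the top of the range. For compound 4 the estimate is 1800000 nM, with a range from 700000 nM to 4500000 nM. This estimate means an expected step of a 1.3-fold higher number from compound 2 to compound 4 (0.11 log units; within the scatter), probably not beyond the scatter.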

Compound 4, half-maximal cytotoxic concentration: 1060000 nM
Estimate against measurement, compound 4: 1.7-fold (0.23 log units) above, within the range that was stated.
By their numbers in this assay, from the lowest: compounds 1, 3, 4 and 2 (each within the scatter of the next, the first and the last beyond it).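

In this assay this place on the five-membered aromatic ring tolerates a large exchange of groups (a 1.3-fold lower number from compound 2 to compound 4 (0.12 log units; within the scatter)). Hydroxymethyl brings no ring where 4-nitrophenyl brought a six-membered aromatic ring of carbon only, yet compound 4 lies within the scatter of compound 2. Nothing at hand bears on why the exchange reads this way.

The compounds shown leave open whether an amine, a carboxylic acid or a longer chain at this place would read the same. They also leave open how hydroxymethyl reads with hydrogen in place of fluoro on the core, or with the configuration drawn in compound 3.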